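From propylsulfanyl to benzylamino on the shared core

The source may report more compounds than this note shows. Statements on the series, on what has been measured and on what is new or still open speak of the compounds shown alone.

Going by the values given here, in an ADME assay on CCRF-HSB-2 cells (Homo sapiens) for cytotoxicity, with a stated time of 7 days (a lower number here means that less compound is tolerated, a higher number that more compound is tolerated), compound 3 `CCCSc1nc(N)nc2c1ncn2/C=C1/CC1(CO)CO` gives 98000 nM, the only actual number so far. Compound 1 `CNc1nc(N)nc2c1ncn2/C=C1/CC1(CO)CO` reports only a limit, > 20000 nM. Compound 2 `COCCOc1nc(N)nc2c1ncn2/C=C1/CC1(CO)CO` likewise reports only a limit, > 20000 nM. The measured set is thus largely defined by the limit of > 20000 nM in this assay, at which 2 of the 3 values shown sit.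

Compound 4 `Nc1nc(NCc2ccccc2)c2ncn(/C=C3/CC3(CO)CO)c2n1` has benzylamino in place of the propylsulfanyl of compound 3 on an aromatic carbon: benzylamino in place of propylsulfanyl on an aromatic carbon.

Two measured changes at this same place bear on it: a step that the limit leaves unreadable from compound 1 to compound 3, and a step that the limit leaves unreadable from compound 2 to compound 3. Neither gives a usable size or direction. Compound 1 is the closer guide, since it also carries an amino group there, but it offers only its limit. With no readable step to carry over, the working expectation stays anchored on compound 3 at 98000 nM.

The expected change is a 1.6-fold lower number from compound 3 to compound 4 (0.21 log units; within the scatter), with no step beyond the scatter anticipated in this assay. For compound 4 the estimate is 60000 nM, with an expected range of 20000 nM to 150000 nM.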

Compound 4, half-maximal cytotoxic concentration: > 20000 nM
Compound 4 ended at the assay's limit (the forecaster's own chance of this, stated with the estimate: 50%); the middle value lies beyond the limit too.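

In this assay, going by these compounds alone, compound 4 gives > 20000 nM, a limit and not a number, so no step from compound 1, compound 2 or compound 3 to compound 4 can be read. Whether methylamino, 2-methoxyethoxy or benzylamino truly differs from propylsulfanyl at this place, and in which direction, stays open: the limit of > 20000 nM in this assay, at which 3 of the 4 values shown sit.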